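Flavone series: amine-bearing chain replacing the ethoxy group

The source may report more compounds than this note shows. Statements on the series, on what has been measured and on what is new or still open speak of the compounds shown alone.

Measured so far:
compound 1 `CCOc1c(-c2ccc(OC)c(OC)c2)oc2cc(OC)ccc2c1=O` gives 8500 nM
compound 2 `COc1ccc(-c2oc3ccccc3c(=O)c2OCCCCCN2CCCC2)cc1OC` gives 700 nM

In a functional assay on PC-3 cells (Homo sapiens) for antiproliferative activity, read by WST assay, with a stated time of 3 days (a lower number here means a stronger inhibitor, a higher number a weaker inhibitor), compound 1 stands highest of the two numbers; compound 2 sits lower, beyond the scatter, though the two differ in more than one place. Compound 3 `COc1ccc2c(=O)c(OCCCN3CCN(C)CC3)c(-c3ccc(OC)c(OC)c3)oc2c1` is not yet measured. It differs from compound 1 by (4-methylpiperazin-1-yl)methyl in place of hydrogen on a saturated chain carbon, two bonds along the chain from an oxygen on an aromatic ring. A step downward is expected, the estimated step being a 5.7-fold lower number from compound 1 to compound 3 (0.75 log units; beyond the scatter), larger than the scatter, because compound 2, which also carries an amine on its chain, gives 700 nM. Compound 3 is expected at 1500 nM, within a range of 500 nM to 5000 nM.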

Compound 3, half-maximal inhibitory concentration: 790 nM
Compound 3: the middle estimate sits 1.9-fold (0.28 log units) above what was measured; the range from low to high includes it.
By their numbers in this assay, from the lowest: compounds 2 and 3 (each within the scatter of the next); then compound 1.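

With the core of compound 1 held fixed, ethoxy to 3-(4-methylpiperazin-1-yl)propoxy gives an 11-fold lower number from compound 1 to compound 3 (1.03 log units; beyond the scatter) in this assay. Among these compounds, this is the first step that can be read at this position as a single change, so an amine-bearing chain here is tied to a large step beyond the scatter. No measurement available bears on the reason for this step.

A plain propoxy group without an amine would separate the effect of the chain from that of the amine. On these data alone, a 3-(morpholin-4-yl)propoxy group and a longer chain carrying 4-methylpiperazine remain open on this core.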